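Bromo for Chloro: Expectation for Compound 4

The source may hold more compounds than are shown below. What is called first, only, known or untested is meant among the compounds shown, and "the series" means these compounds.

Compound 1 `O=C1C(=O)N(CN2CCN(c3ccnc4cc(Cl)ccc34)CC2)c2cc(Cl)ccc21` and compound 2 `O=C1C(=O)N(CN2CCN(c3ccnc4cc(Cl)ccc34)CC2)c2cc(Br)ccc21` share one core and differ only by bromo in place of chloro on an aromatic carbon. In a functional assay on MDA-MB-468 cells (Homo sapiens) for cytotoxicity, read by sulforhodamine B assay, with a stated time of 48 h (a higher number here means a weaker inhibitor of growth, a lower number a stronger inhibitor of growth), compound 1 gives 36600 nM, and compound 2 gives 35800 nM; the step is a 1.0-fold lower number from compound 1 to compound 2 (0.01 log units; within the scatter). Compound 3 `NC(=S)N/N=C1/C(=O)N(CN2CCN(c3ccnc4cc(C(F)(F)F)ccc34)CC2)c2cccc(Cl)c21` rests on another core; the difference between the two cores is not broken down here. In this assay compound 3 gives 23000 nM. Compound 4 `NC(=S)N/N=C1/C(=O)N(CN2CCN(c3ccnc4cc(C(F)(F)F)ccc34)CC2)c2cccc(Br)c21` has not been measured; it differs from compound 3 by bromo in place of chloro on an aromatic carbon. This is the same kind of change as between compound 1 and compound 2, though the surroundings differ: here the carbon is ortho to a fused ring and meta to a fused ring, whereas before it was meta to a fused ring and para to a fused ring. Because the earlier step was a 1.0-fold lower number from compound 1 to compound 2 (0.01 log units; within the scatter), the new step is expected to be no change at the digits printed from compound 3 to compound 4 (within the scatter). Compound 4 is estimated at 23000 nM, likely between 12000 nM and 45000 nM.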

Compound 4, concentration for 50% growth inhibition: 30400 nM
Compound 4: the middle estimate sits 1.3-fold (0.12 log units) below what was measured; low and high end bracket the measured number.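

In this assay, bromo in place of chloro on the core of compound 3 gives a 1.3-fold higher number from compound 3 to compound 4 (0.12 log units; within the scatter), so this step, like the earlier one, stays within the usual scatter. Set side by side, the two steps do not differ by more than repeated measurements would: the same change on two cores in this assay, a 1.0-fold lower number (0.01 log units; within the scatter) from compound 1 to compound 2 and a 1.3-fold higher number (0.12 log units; within the scatter) from compound 3 to compound 4, 1.4-fold (0.13 log units) apart, within the scatter of two such steps. Among the compounds shown here, this shows that the swap left the number unchanged within the scatter on both cores, but it rests on only two pairs of compounds in one cell line and cannot show that the same would hold on other cores.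

The compounds shown leave open what a group other than chloro or bromo, such as a methoxy or an amine, would do on this aromatic carbon. They also leave open whether bromo for chloro behaves the same way on other ring carbons.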